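Will a double stereocentre swap change growth inhibition?

This account rests on a few compounds, and the source may have more. Where it says the series, first, only, none or still open, it means among the compounds named here.

In a functional assay on HeLa cells (Homo sapiens) for antiproliferative activity, read by sulforhodamine B assay (on this read-out lower numbers stand for stronger inhibition of growth and higher numbers for weaker inhibition of growth), compound 1 `O[C@H]1CO[C@H](COCc2ccccc2)[C@@H](OCc2ccccc2)[C@@H]1OCc1ccccc1` gives > 50000 nM, which is a limit and not a number. Compound 2 `CCC[C@@H]1O[C@H](COCc2ccccc2)[C@@H](OCc2ccccc2)[C@H](OCc2ccccc2)[C@H]1O` gives 18900 nM, and compound 3 `CCC[C@H]1O[C@H](COCc2ccccc2)[C@@H](OCc2ccccc2)[C@H](OCc2ccccc2)[C@H]1O` gives 17400 nM. These two numbers stand level within the scatter, so compound 3 shares its place with compound 2. Putting propyl in place of hydrogen on a saturated ring carbon gave an at least 2.6-fold lower number from compound 1 to compound 2 (0.42 log units; beyond the scatter) and an at least 2.8-fold lower number from compound 1 to compound 3 (0.45 log units; beyond the scatter), sizes that rest on (the limit of > 50000 nM in this assay, at which 1 of the 3 values shown sits). Those steps add atoms, so they say little here.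

Compound 4 `CCC[C@@H]1O[C@H](COCc2ccccc2)[C@@H](OCc2ccccc2)[C@H](OCc2ccccc2)[C@@H]1O` brings a different kind of change: the two compounds have the same atoms and bonds and differ only in configuration as drawn: 2 of 5 stereo elements differ; a stereocentre at a saturated ring carbon is drawn R in compound 3 and S in compound 4; a stereocentre at a saturated ring carbon is drawn S in compound 3 and R in compound 4. The closest measured precedent is a 1.1-fold lower number from compound 2 to compound 3 (0.04 log units; within the scatter), and it reflects (the fact that compounds 2 and 3 differ only in the configuration as drawn). That step changed one stereo element and stayed within the scatter, whereas this change involves two, so some uncertainty remains. The expected result is a 1.0-fold higher number from compound 3 to compound 4 (0.01 log units; within the scatter), with no shift beyond the scatter as the likeliest outcome. For compound 4 the estimated value is 18000 nM, with an expected range of 7000 nM to 45000 nM.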

Compound 4, concentration for 50% growth inhibition: 23300 nM
The estimate for compound 4 lay 1.3-fold (0.11 log units) below the measured number; low and high end bracket the measured number.
By their numbers in this assay, from the lowest: compounds 3, 2 and 4 (each within the scatter of the next). At a limit, above all of these: compound 1.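

The new compound shows that changing two stereocentres together does no more in this assay than changing one: the double swap gives a 1.3-fold higher number from compound 3 to compound 4 (0.13 log units; within the scatter). Among these compounds, a single swap at a second stereocentre, not the one changed between compounds 2 and 3, gives a 1.2-fold higher number from compound 2 to compound 4 (0.09 log units; within the scatter). Compounds 2, 3 and 4 therefore stand level, and since they share all their atoms and bonds, these two ring carbons are the only place where they differ: the fact that compounds 3 and 4 differ only in the configuration as drawn

Going by these compounds, the other three stereo elements are the same across compounds 2, 3 and 4, so what changing them would do remains open. Also open, on these data alone, is whether these swaps would still leave the numbers level if a longer chain or an amine replaced propyl on the ring.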